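Pyridinyl for thiazolyl on the sulfonamide nitrogen

The source may report more compounds than this note shows. Statements on the series, on what has been measured and on what is new or still open speak of the compounds shown alone.

Measured so far in a functional assay on A549 cells (Homo sapiens) for cytotoxicity, read by sulforhodamine B assay, with a stated time of 72 h; on this read-out lower numbers stand for stronger inhibition and higher numbers for weaker inhibition:
Compound 1, `O=c1c(CNc2ccc(S(=O)(=O)Nc3nccs3)cc2)coc2ccccc12`: 25600 nM
Compound 2, `O=C1/C(=C/c2coc3ccccc3c2=O)N=C(c2ccccc2)N1c1ccc(S(=O)(=O)Nc2ncccn2)cc1`: 40500 nM
Compound 3, `NS(=O)(=O)c1ccc(NC2=NC(=O)/C(=C\c3coc4ccccc4c3=O)S2)cc1`: 2230 nM

Compound 1 stands at the weak end of this small set. Its number and that of compound 2 lie within the scatter of each other, so no order can be drawn between them. Compound 3 alone is set apart: its number is far lower than that of compound 1, a gap well beyond the scatter.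

Compound 4, `O=c1c(CNc2ccc(S(=O)(=O)Nc3ccccn3)cc2)coc2ccccc12`, has not yet been measured. It differs from compound 1 in one place: pyridin-2-yl in place of 1,3-thiazol-2-yl on a sulfonamide nitrogen. No step between two measured compounds mirrors this change, so nothing among the numbers shown says how large its effect will be.

With nothing to point either way, the step from compound 1 to compound 4 is expected to be small, a 1.0-fold lower number from compound 1 to compound 4 (0.01 log units; within the scatter), within the usual scatter rather than beyond it. Compound 4 is therefore estimated at 25000 nM in this assay, with a range from 8000 nM to 70000 nM.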

Compound 4, half-maximal inhibitory concentration: > 100000 nM
Compound 4: a limit, no number; the forecaster's own chance of this, stated with the estimate: 15%; middle value at least 4.0-fold (0.60 log units) from the limit.
By their numbers in this assay, from the lowest: compound 3; then compounds 1 and 2 (each within the scatter of the next). At a limit, above all of these: compound 4.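

In this assay, pyridin-2-yl in place of 1,3-thiazol-2-yl on the sulfonamide nitrogen gives an at least 3.9-fold higher number from compound 1 to compound 4 (0.59 log units; beyond the scatter) and so shows that the core of compound 1 is not indifferent to the ring carried at this place. Among these compounds, no earlier pair of measured compounds could show this, since none differed by a single change. The result for compound 4 is a limit and not a number: the limit of > 100000 nM in this assay, at which 1 of the 4 values shown sits.

Among the compounds shown here, with only this one step, it remains open whether the five-membered ring size, the hetero atoms or something else in the change matters. The compounds shown also leave open how the same core would respond to a 1,3-oxazol-2-yl ring or a methyl group on the sulfonamide nitrogen.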